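Extending a sulfur-linked chain on a guanidine-bearing core

The compounds below may be only part of what the source reports. "The series", "measured", "known", "first", "only" and "open" are said of these compounds alone.

Compound 1 `CCCc1cc(C)c(C(=O)N=C(N)N)cc1S(C)(=O)=O`, compound 2 `CCC(C)c1cc(C)c(C(=O)N=C(N)N)cc1S(C)(=O)=O` and compound 3 `CCSc1cc(C)c(C(=O)N=C(N)N)cc1S(C)(=O)=O` were all tested in a functional assay for inhibition of sodium/hydrogen exchanger (Oryctolagus cuniculus); a higher number here means a weaker inhibitor, a lower number a stronger inhibitor. Compound 1 gives 5.7 nM, compound 2 gives 8 nM and compound 3 gives 5.9 nM. The change methyl in place of hydrogen on a saturated chain carbon bound to an aromatic carbon and a saturated chain carbon produced a 1.4-fold higher number from compound 1 to compound 2 (0.15 log units; within the scatter). The cores of compound 1 and compound 3 differ by ethylsulfanyl in place of propyl on an aromatic carbon. That difference gave a 1.0-fold higher number from compound 1 to compound 3 (0.01 log units; within the scatter), and the remaining pair shows a 1.4-fold lower number from compound 2 to compound 3 (0.13 log units; within the scatter). All three numbers thus sit close together.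

Compound 4 `CCCSc1cc(C)c(C(=O)N=C(N)N)cc1S(C)(=O)=O` has not yet been measured. It differs from compound 3 by methyl in place of hydrogen on a saturated chain carbon, two bonds along the chain from a sulfur. Within the data shown here, this is the same kind of change as the one separating compound 1 and compound 2, though its surroundings are not the same: there the added carbon sat on a saturated chain carbon bound to an aromatic carbon and a saturated chain carbon, here it sits on a saturated chain carbon, two bonds along the chain from a sulfur. Because the earlier step was a 1.4-fold higher number from compound 1 to compound 2 (0.15 log units; within the scatter), the expected step here is of similar small size, namely a 1.2-fold higher number from compound 3 to compound 4 (0.07 log units; within the scatter). Compound 4 is therefore estimated to give about 7 nM in this assay, with a likely range from 3.5 nM to 14 nM.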

Compound 4, half-maximal inhibitory concentration: 6.8 nM
For compound 4 the middle estimate is 1.0-fold (0.01 log units) above the measured one, and the stated range covers the measured number.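

In this assay, the methyl that turns ethylsulfanyl into propylsulfanyl gave a 1.2-fold higher number from compound 3 to compound 4 (0.06 log units; within the scatter), and this step can be set beside the same change on the other core: the same change on two cores in this assay, a 1.4-fold higher number (0.15 log units; within the scatter) from compound 1 to compound 2 and a 1.2-fold higher number (0.06 log units; within the scatter) from compound 3 to compound 4, 1.2-fold (0.09 log units) apart, within the scatter of two such steps.
So the two cores show no detectable difference in this change, and propylsulfanyl in place of sec-butyl (a 1.2-fold lower number from compound 2 to compound 4 (0.07 log units; within the scatter)) and in place of propyl (a 1.2-fold higher number from compound 1 to compound 4 (0.08 log units; within the scatter)) also leaves the numbers within the scatter. This does not show that the added carbon has a fixed effect: each of these steps is too small to tell apart from repeat-measurement noise, and two pairs of compounds support no rule beyond these four.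

The compounds shown leave open whether a longer chain on the sulfur, such as butylsulfanyl, would also stay within the scatter. They also leave open what an amine or a carboxylic acid in place of the propylsulfanyl would do in this assay.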